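The compounds below may be only part of what the source reports. "The series", "measured", "known", "first", "only" and "open" are said of these compounds alone.

Working notes on the series.

Compound 1 `CC(C)C(=O)OCOC(=O)C1=C(S[C@@H]2CN[C@H](C(=O)Nc3cccc(C(=O)OCOC(=O)C(C)C)c3)C2)[C@H](C)[C@@H]2[C@@H]([C@@H](C)O)C(=O)N12`, compound 2 `C[C@@H](O)[C@H]1C(=O)N2C(C(=O)O)=C(S[C@@H]3CN[C@H](C(=O)Nc4cccc(C(=O)OCC(F)(F)F)c4)C3)[C@H](C)[C@H]12` and compound 3 `C[C@@H](O)[C@H]1C(=O)N2C(C(=O)OCC(F)(F)F)=C(S[C@@H]3CN[C@H](C(=O)Nc4cccc(C(=O)OCC(F)(F)F)c4)C3)[C@H](C)[C@H]12` share one core and have all been run in a physicochemical assay for metabolic stability, read by LC-MS, in phosphate buffer, with a stated time of 3 h, at pH 7.4, tested at 50 uM; a lower number here means that less of the compound is left, a higher number that more of the compound is left. For compound 1 the read is a limit of the assay, > 95%. For compound 2 the read is likewise a limit, > 95%. For compound 3 the read is again a limit, > 95%. Compound 2 therefore stands at the upper limit of this assay, and so do both other values shown, as the limit of > 95% in this assay, at which 3 of the 3 values shown sit, records. Among the measured compounds shown here, the only single-point step among the measured compounds, a step that the two limits leave unreadable from compound 2 to compound 3, cannot be given a size, as both of its ends are limits.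

Compound 4 `C[C@@H](O)[C@H]1C(=O)N2C(C(=O)O)=C(S[C@@H]3CN[C@H](C(=O)Nc4cccc(C(=O)OCOC(=O)C(C)(C)C)c4)C3)[C@H](C)[C@H]12` differs from compound 2 in one place: ((tert-butyl)carbonyl)oxy in place of trifluoromethyl on a saturated chain carbon bound to an oxygen next to a carbonyl group. For the measured compounds named here, the step from compound 2 to compound 3 is the only measured step that touches the oxygen next to a carbonyl group, and it is unreadable, so no measured step gives a size for the change at hand. With all three values at the limit, the expectation for compound 4 in this assay is the same limit, and the expected step is a step that the limit leaves unreadable from compound 2 to compound 4, none beyond the scatter. Compound 4 is estimated at 96%, within 85% to 99%.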

Compound 4, percent of the compound remaining: > 95%
Compound 4: no number, only a limit (the forecaster's own chance of this, stated with the estimate: 70%); the middle value does not contradict the limit.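

No new step can be read: compound 2 and compound 4 both sit at a limit in this assay, so the size of the change between them stays unreadable. The compounds shown leave open whether compound 1, compound 2, compound 3 and compound 4 differ at all in this assay, and what any single change does there.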